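The compounds below may be only part of what the source reports. "The series", "measured", "known", "first", "only" and "open" are said of these compounds alone.

Compound 1 `O=C(O)CCCSCCN1C(=O)OC[C@@H]1/C=C/[C@@H](O)Cc1ccccc1` shows little binding in an assay on CHO cells for displacement of a labelled ligand from prostaglandin E2 receptor EP2 subtype (Mus musculus), read by scintillation counting, with a stated time of 60 min; a lower number here means a stronger inhibitor, a higher number a weaker inhibitor: in this assay compound 1 gives > 10000 nM, which is a limit of the assay and not a measured number. Compound 1 thus sits at the limit of > 10000 nM in this assay, at which 1 of the 2 values shown sits. Within the data shown here, compound 2 `CCCc1cccc(C[C@H](O)/C=C/[C@H]2CCC(=S)N2CCCCCCC(=O)O)c1`, built on a different core, gives 6800 nM in this assay, a measured value, and no step between compound 1 and compound 2 is worked out here, so only the two values themselves can be compared. Compound 3 `O=C(O)CCCSCCN1C(=O)OC[C@@H]1/C=C/[C@@H](O)Cc1cccc(C(F)(F)F)c1` keeps all of compound 1 and differs in one place: trifluoromethyl in place of hydrogen on an aromatic carbon. Among the measured compounds shown here, with compound 1 standing only at a limit, no measured step in this set shows how large a change this substitution brings. The expected step from compound 1 to compound 3 is an at least 1.4-fold lower number from compound 1 to compound 3 (0.15 log units; that floor lies within the scatter), a modest gain that may not reach beyond the scatter. Compound 3 is therefore estimated at 7000 nM, with a range from 2000 nM to 20000 nM.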

Compound 3, inhibition constant: > 10000 nM
Compound 3 ended at the assay's limit (the forecaster's own chance of this, stated with the estimate: 55%); middle value at least 1.4-fold (0.15 log units) away from the limit.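

Compound 1 and compound 3 both stand at a limit of this assay and not at a measured number, so no step between them can be read: the limit of > 10000 nM in this assay, at which 2 of the 3 values shown sit.

Going by these compounds, whether trifluoromethyl in place of hydrogen on an aromatic carbon changes binding at all, and by how much, stays open.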